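Working notes: a ring isomer of compound 3

The source may hold more compounds than are shown below. What is called first, only, known or untested is meant among the compounds shown, and "the series" means these compounds.

Values in a physicochemical assay for lipophilicity, using the shake flask method, measured as octanol-water partition, at pH 7.4; a lower number here means a more polar compound, a higher number a more lipophilic compound:
compound 1 `CC(=O)N[C@@H]1CCC[C@H](C(=O)Nc2cc(-c3cnn(C)c3C)c(Cl)cn2)C1`: 2.6
compound 2 `CC(=O)N[C@@H]1CCC[C@H](C(=O)Nc2cc(-c3cnc4n3CCCC4)c(Cl)cn2)C1`: 2.7
compound 3 `CC(=O)N[C@@H]1CCC[C@H](C(=O)Nc2cc(-c3cnn4c3COCC4)c(Cl)cn2)C1`: 2.4

Compound 3, at 2.4, stands within the scatter of both other compounds. Compound 4 `CC(=O)N[C@@H]1CCC[C@H](C(=O)Nc2cc(-c3cnn4c3OCCC4)c(Cl)cn2)C1` has the same atoms as compound 3, joined differently: a group of 9 heavy atoms (6 carbon, 2 nitrogen, 1 oxygen; one five-membered aromatic ring with 2 hetero atoms, one six-membered non-aromatic ring with 2 hetero atoms) in place of a group of 9 heavy atoms (6 carbon, 2 nitrogen, 1 oxygen; one five-membered aromatic ring with 2 hetero atoms, one six-membered non-aromatic ring with 2 hetero atoms), on an aromatic carbon. The change lies ortho to a chloro group. The measured changes at this place are a number 0.10 log units higher from compound 1 to compound 2 (within the scatter), a number 0.20 log units lower from compound 1 to compound 3 (within the scatter) and a number 0.30 log units lower from compound 2 to compound 3 (within the scatter). None leaves the scatter, so no step beyond it is expected in either direction, although none of them rearranges the same atoms. The expected step is a number 0.10 log units higher from compound 3 to compound 4 (within the scatter). Compound 4 is estimated at 2.5, with an expected range of 2.1 to 2.9.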

Compound 4, distribution coefficient: 2.6
The estimate for compound 4 lay 0.10 log units below the measured number; the range from low to high includes it.
By their numbers in this assay, from the lowest: compounds 3, 1, 4 and 2 (each within the scatter of the next).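

In this assay, rearranging the same atoms on this aromatic carbon, ortho to a chloro group, gives a number 0.20 log units higher from compound 3 to compound 4 (within the scatter), the first such rearrangement read at this position. The other new steps are a number 0.10 log units lower from compound 2 to compound 4 (within the scatter) and no change at the digits printed from compound 1 to compound 4 (within the scatter), so all four groups at this position stay within the scatter of one another. No measurement available accounts for the values of these isomers.

From the compounds shown here alone, whether an amine or a carboxylic acid at this position would give a step beyond the scatter remains open.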